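A Dichlorophenyl Exchange in a Narrow Cytotoxicity Series

The source may hold more compounds than are shown below. What is called first, only, known or untested is meant among the compounds shown, and "the series" means these compounds.

Of the compounds shown here, three sharing one core have been measured in a functional assay on MCF7 cells (Homo sapiens) for cytotoxicity, read by MTT assay, with a stated time of 72 h; on this read-out lower numbers stand for stronger inhibition and higher numbers for weaker inhibition. Compound 1 (`COc1ccc(/C=C2\CCC/C(=C\c3ccccc3Cl)C2=O)cc1OC`) gives 10400 nM, compound 2 (`COc1ccc(/C=C2\CCC/C(=C\c3ccc(O)cc3)C2=O)cc1OC`) gives 17000 nM, and compound 3 (`COc1ccc(/C=C2\CCC/C(=C\c3ccc(Cl)cc3Cl)C2=O)cc1OC`) gives 16200 nM. Compound 3 stands within the scatter of both compound 1 and compound 2, so these numbers set no order among the three.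

The next compound, compound 4 (`COc1ccc(/C=C2\CCC/C(=C\c3ccc(Cl)c(Cl)c3)C2=O)cc1OC`), has the same atoms as compound 3, joined differently: 3,4-dichlorophenyl in place of 2,4-dichlorophenyl on a double-bonded chain carbon bound to a double-bonded ring carbon. Within the data shown here, no measured step shows this exchange directly, so the evidence is indirect. Adding a chloro on an aromatic carbon gave a 1.6-fold higher number from compound 1 to compound 3 (0.19 log units; within the scatter). Exchanging the aryl group on the double-bonded chain carbon gave a 1.6-fold higher number from compound 1 to compound 2 (0.21 log units; within the scatter) and a 1.0-fold lower number from compound 2 to compound 3 (0.02 log units; within the scatter). All three steps lie within the scatter, including the one that brings in a second chloro and the one that replaces a hydroxyl-bearing ring with a dichlorinated one.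

No step beyond the scatter is expected for the new exchange in this assay, and the measurements favour no direction. The estimated step is a 1.2-fold lower number from compound 3 to compound 4 (0.06 log units; within the scatter), which is expected to stay within the scatter. Compound 4 is expected at 14000 nM, with an estimated range of 7000 nM to 28000 nM.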

Compound 4, half-maximal inhibitory concentration: 4400 nM
Estimate against measurement, compound 4: 3.2-fold (0.50 log units) above, and the stated range ends above it.
By their numbers in this assay, from the lowest: compound 4; then compounds 1, 3 and 2 (each within the scatter of the next).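

Among these compounds, the result in this assay shows that the aryl group on a double-bonded chain carbon bound to a double-bonded ring carbon can move the number beyond the scatter, which no earlier step had done: the exchange of 2,4-dichlorophenyl for 3,4-dichlorophenyl keeps the same atoms yet gives a clear difference (a 3.7-fold lower number from compound 3 to compound 4 (0.57 log units; beyond the scatter)). The 3,4-dichlorophenyl group also separates from the other two aryl groups, both from 4-hydroxyphenyl (a 3.9-fold lower number from compound 2 to compound 4 (0.59 log units; beyond the scatter)) and from 2-chlorophenyl (a 2.4-fold lower number from compound 1 to compound 4 (0.37 log units; beyond the scatter)). Carrying two chloro atoms is therefore not enough in itself, since compound 3 carries two as well and stays within the scatter of compound 1 and compound 2, and nothing available here accounts for the difference between the two dichlorophenyl groups.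

The compounds shown leave open whether the lower number is tied to chloro itself or would also appear with 3,4-dibromophenyl or 3,4-dimethylphenyl at this place. They also leave open how an aryl group carrying an amine or a carboxylic acid would read here, and whether the order seen on these cells holds in any other cell line.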